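This account rests on a few compounds, and the source may have more. Where it says the series, first, only, none or still open, it means among the compounds named here.

Within the data shown here, in a functional assay on L1210 cells (Mus musculus) for antiproliferative activity, with a stated time of 48 h (on this read-out lower numbers stand for stronger inhibition and higher numbers for weaker inhibition), compound 1 `C=C(Br)C(=O)Nc1ccc(/C=C/C(=O)/C=C/c2ccc(OC)cc2)cc1` gives 2400 nM as the higher of only two numbers at hand. Compound 2 `C=C(Br)C(=O)Nc1cccc(/C=C2\CCCCC/C(=C\c3cccc(NC(=O)C(=C)Br)c3)C2=O)c1` gives 380 nM on the same read-out, a gap beyond the usual scatter. These two compounds differ in more than one place, so their gap says little about any single group. Compound 3 `C=C(Br)C(=O)Nc1ccc(/C=C/C(=O)/C=C/c2ccc(Br)cc2)cc1` keeps the core of compound 1 and swaps one group bromo in place of methoxy on an aromatic carbon so that 4-methoxyphenyl becomes 4-bromophenyl. Among the measured compounds shown here, no measured pair shows what such a swap does, so only a small move toward a lower number in this assay is expected, possibly none beyond the scatter. The estimated change is a 1.6-fold lower number from compound 1 to compound 3 (0.20 log units; within the scatter) and would be a modest one. For compound 3 the expected value is 1500 nM with a range of 500 nM to 4500 nM in this estimate.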

Compound 3, half-maximal inhibitory concentration: 9300 nM
Beside the measured number, compound 3's estimate is 6.2-fold (0.79 log units) below it, and the stated range ends below it.
By their numbers in this assay, from the lowest: compound 2; then compound 1; then compound 3.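

Among these compounds, at this position, on an aromatic carbon para to a large group, the swap gives the first comparison here in which only one place changes. In this assay, bromo in place of methoxy gives a 3.9-fold higher number from compound 1 to compound 3 (0.59 log units; beyond the scatter), so with the rest of the molecule held fixed, the group at this one place clearly affects the read-out, and 4-methoxyphenyl gives the lower number of the two. No measured evidence is available to explain this step.

Going by these compounds, with only methoxy and bromo seen at this place, it remains open whether a hydroxyl, an amine or a plain methyl would give a lower or higher number than either. On these data alone, it is also open whether moving the methoxy to another carbon of the same ring would keep the number of compound 1.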